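Replacing an aminophenyl with a fluorophenyl: what to expect

A few compounds are considered here, and "the series" means these few. Any claim that something is new, unique, unknown or untested is made for them only; others in the source may bear on it.

Measured so far:
Compound 1 `Nc1cccc(-c2cn(CC(=O)Nc3nccs3)nn2)c1` gives 1270 nM.
Compound 2 `Cc1csc(NC(=O)Cn2cc(-c3cccc(N)c3)nn2)n1` gives 250 nM.
Compound 3 `COC(=O)c1ccc(-c2cn(CC(=O)Nc3nc4ccccc4s3)nn2)cc1` reaches only a limit, > 30000 nM.

In a functional assay on BMDM cells (Mus musculus, strain C57BL/6) for inhibition, with a stated time of 2 days (a higher number here means a weaker inhibitor, a lower number a stronger inhibitor), compound 1 stands highest of the two numbers shown; its nearest neighbour is reached by a 5.1-fold lower number from compound 1 to compound 2 (0.71 log units; beyond the scatter), a methyl in place of hydrogen on an aromatic carbon. Among the compounds with values here, compound 3 sits at the limit described by the limit of > 30000 nM in this assay, at which 1 of the 3 values shown sits, and differs from compound 1 in two places, so it offers no single step. Compound 4 `O=C(Cn1cc(-c2ccc(F)cc2)nn1)Nc1nccs1` differs from compound 1 by 4-fluorophenyl in place of 3-aminophenyl on an aromatic carbon. Within the data shown here, no measured step bears on this change. With nothing to build on, the step of a 2.4-fold higher number from compound 1 to compound 4 (0.37 log units; beyond the scatter) is expected to be small, weakening by a little. Compound 4 is therefore estimated at 3000 nM, likely between 700 nM and 15000 nM.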

Compound 4, half-maximal inhibitory concentration: 190 nM
For compound 4 the middle estimate is 16-fold (1.20 log units) above the measured one, outside the stated range (below it).
By their numbers in this assay, from the lowest: compounds 4 and 2 (each within the scatter of the next); then compound 1. At a limit, above all of these: compound 3.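

In this assay, 4-fluorophenyl in place of 3-aminophenyl gives a 6.7-fold lower number from compound 1 to compound 4 (0.83 log units; beyond the scatter). The amine is therefore not needed for activity at this position in this series: the entering group counts no hydrogen-bond donor or acceptor, yet the number falls. The compounds shown give no measurement that explains this fall.

The swap changes both the substituent and where it sits on the phenyl ring, so the effect of each remains unseparated. A plain phenyl or a 4-chlorophenyl at this position would help tell them apart.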